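Methylating a Phenol Oxygen on a Second Core

The source may report more compounds than this note shows. Statements on the series, on what has been measured and on what is new or still open speak of the compounds shown alone.

Four compounds are considered, two on each of two cores. Compound 1 `C=CCc1ccc(OC)c(-c2cc(CCC)on2)c1` and compound 2 `C=CCc1ccc(O)c(-c2cc(CCC)on2)c1` share one core; compound 3 `C=CCn1ccc(-c2cc(Br)ccc2O)n1` and compound 4 `C=CCn1ccc(-c2cc(Br)ccc2OC)n1` share another. The difference between the two cores is not broken down here.

Three of them have been tested in a functional assay on BV-2 cells (Mus musculus) for inhibition, read by Griess assay, with a stated time of 24 h; on this read-out lower numbers stand for stronger inhibition and higher numbers for weaker inhibition. In this assay compound 1 gives only a limit, > 200000 nM. In this assay compound 2 also gives only a limit, > 200000 nM. Among the measured compounds shown here, compound 3 is the one compound with a true number, giving 112000 nM in this assay.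

The change from compound 2 to compound 1 is methyl in place of hydrogen on an oxygen on an aromatic ring. Its step, a step that the two limits leave unreadable from compound 2 to compound 1, cannot be read because both values sit at the limit of > 200000 nM in this assay, at which 2 of the 3 values shown sit. The change from compound 3 to compound 4 is methyl in place of hydrogen on an oxygen on an aromatic ring; the place is described in the same words for both pairs, so this is the same change carried onto a different core.

For the measured compounds named here, the earlier example leaves no readable step, so the only anchor for compound 4 is the measured value of compound 3. The step expected in this assay is a 1.3-fold higher number from compound 3 to compound 4 (0.13 log units; within the scatter), kept small in the absence of any readable precedent. For compound 4 the expected value in this assay is 150000 nM, with a plausible range from 40000 nM to 400000 nM, and a real chance that only a limit is reported.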

Compound 4, half-maximal inhibitory concentration: > 200000 nM
Compound 4: only a limit was reported; the forecaster's own chance of this, stated with the estimate: 40%; at least 1.3-fold (0.12 log units) between middle value and limit.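

In this assay compound 4 gives only a limit, > 200000 nM. Going by these compounds, changing hydroxy to methoxy on this core therefore gives an at least 1.7-fold higher number from compound 3 to compound 4 (0.25 log units; that floor lies within the scatter), which means that the true size of the step is unknown: it may be no larger than the usual scatter, or it may be much larger, so a real weakening of inhibition is not established. Whether the change acts in the same way on both cores cannot be told, and neither can its size on the first core, because compound 1 and compound 2 give only limits, as compound 4 does: the limit of > 200000 nM in this assay, at which 3 of the 4 values shown sit.

The compounds shown leave open whether any other group on that oxygen, such as a longer chain like ethyl, or a chain ending in an amine or a carboxylic acid, would give stronger or weaker inhibition than the hydroxy of compound 3. Among the compounds shown here, they also leave open how far the number of compound 3 depends on its bromine, since no compound here replaces that atom with another group, and compound 3 remains the only compound of the four with a true number to compare against.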